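Ring-nitrogen substituent size in the dipropylamino series

The compounds below may be only part of what the source reports. "The series", "measured", "known", "first", "only" and "open" are said of these compounds alone.

Going by the values given here, compound 1 `CCCN(CCC)c1c(C)nc(-c2c(C)cc(C)cc2OC)n(C(C)C)c1=O` stands lowest of the two numbers known so far; in an assay on IMR-32 cells for binding affinity to corticotropin-releasing factor receptor 1 (Homo sapiens) (on this read-out lower numbers stand for stronger inhibition and higher numbers for weaker inhibition), compound 1 gives 47 nM. Compound 2 `CCCN(CCC)c1c(C)nc(-c2c(C)cc(C)cc2C)n(CC)c1=O` differs from compound 1 in two places, one of them on the ring nitrogen, and in this assay compound 2 gives 72 nM; the two values lie within the scatter of each other, so no order between them is drawn. Among the compounds with values here, no pair of measured compounds differs in a single place, so no measured step is available for the change leading to compound 3 `CCCN(CCC)c1c(C)nc(-c2c(C)cc(C)cc2OC)n(C)c1=O`, which differs from compound 1 by methyl in place of isopropyl on an aromatic nitrogen. With nothing measured on this change, the expectation is for a modest rise in the number, toward weaker binding, of a size at or just beyond the scatter. Compound 3 is therefore estimated at 100 nM in this assay, with a range of 40 nM to 250 nM. The step that this estimate means is expected to be a 2.1-fold higher number from compound 1 to compound 3 (0.33 log units; beyond the scatter).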

Compound 3, inhibition constant: 90 nM
Estimate against measurement, compound 3: 1.1-fold (0.05 log units) above; the measured number falls inside the stated range.
By their numbers in this assay, from the lowest: compounds 1, 2 and 3 (each within the scatter of the next).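

Going by these compounds alone, this is the first pair that differs in one place only: methyl in place of isopropyl on an aromatic nitrogen, with the rest of the core of compound 1 unchanged. In this assay this exchange gives a 1.9-fold higher number from compound 1 to compound 3 (0.28 log units; within the scatter) and so, on this read-out, leaves the two compounds inseparable, even though isopropyl with 3 heavy atoms gives way to methyl with 1 heavy atom. Nothing else measured bears on this result, so the numbers offer no explanation for it.

Still open, going by these compounds, is whether a group outside the isopropyl and methyl pair on this nitrogen, such as a longer chain like n-butyl, a benzyl group or a chain ending in an amine, would produce a step beyond the scatter. The ethyl group of compound 2 cannot yet be placed on this step, since compound 2 differs from compound 1 in two places and from compound 3 as well, so the part played by the ethyl group stays unresolved.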